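A methylphenyl in place of a difluorophenyl

This account rests on a few compounds, and the source may have more. Where it says the series, first, only, none or still open, it means among the compounds named here.

In an assay on HEK293 cells for activation of Kir3.1/Kir3.2 (Homo sapiens), read by thallium flux (on this read-out lower numbers stand for an effect already at smaller amounts and higher numbers for an effect only at larger amounts of compound), compound 3 `Cc1cc(NC(=O)Cn2nnc(-c3ccc(F)c(F)c3)n2)n(C2CCCCC2)n1` gives 116 nM, the second highest of the three numbers shown. Its nearest neighbour is compound 2 `Cc1cc(NC(=O)Cn2nnc(-c3cccc(F)c3)n2)n(C2CCCCC2)n1`, which gives 81 nM; a 1.4-fold higher number from compound 2 to compound 3 (0.16 log units; within the scatter). Far away stands compound 1 `Cc1cc(NC(=O)Cn2nnc(-c3ccccn3)n2)n(C2CCCCC2)n1`, which gives 14600 nM; a 180-fold lower number from compound 1 to compound 2 (2.26 log units; beyond the scatter) and a 130-fold lower number from compound 1 to compound 3 (2.10 log units; beyond the scatter). Compound 4 `Cc1cccc(-c2nnn(CC(=O)Nc3cc(C)nn3C3CCCCC3)n2)c1` differs from compound 3 by 3-methylphenyl in place of 3,4-difluorophenyl on an aromatic carbon. The large steps from compound 1 show that a carbon-only ring on that aromatic carbon gives far lower numbers than pyridin-2-yl, while the step from compound 2 to compound 3 shows that a fluoro in place of hydrogen changes little. Compound 4 keeps a carbon-only ring, so the expected step in this assay is a 1.1-fold lower number from compound 3 to compound 4 (0.02 log units; within the scatter), not beyond the scatter. For compound 4 the estimate in this assay is 110 nM, with a range from 35 nM to 350 nM.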

Compound 4, half-maximal effective concentration: 129 nM
Beside the measured number, compound 4's estimate is 1.2-fold (0.07 log units) below it; measured number inside the range.
By their numbers in this assay, from the lowest: compounds 2, 3 and 4 (each within the scatter of the next); then compound 1.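

In this assay, a methyl on the carbon-only ring does as well as fluoro: the data show a 1.1-fold higher number from compound 3 to compound 4 (0.05 log units; within the scatter) and a 1.6-fold higher number from compound 2 to compound 4 (0.20 log units; within the scatter) on this aromatic carbon between two ring nitrogen atoms. The low numbers therefore do not depend on fluorine, as 3-methylphenyl in place of pyridin-2-yl gives a 110-fold lower number from compound 1 to compound 4 (2.05 log units; beyond the scatter) with no fluorine present. No measurement shown here gives a reason for these numbers. On these data alone, it remains open whether a phenyl ring carrying an amine or a carboxylic acid, or a longer chain in place of the methyl, would keep numbers of this size.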